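A ring exchange on compound 2

The source may hold more compounds than are shown below. What is called first, only, known or untested is meant among the compounds shown, and "the series" means these compounds.

Compound 1 (`CSc1cc(C)nc(SC)c1NC(=O)N(Cc1cccc(Oc2ccc(Br)cc2)c1)C1CCCCCC1`): < 0.1 mg/kg as a limit
Compound 2 (`COc1cc(C)nc(OC)c1NC(=O)N(Cc1ccc(Oc2ccc(F)cc2)cc1)C1CCCCCC1`): 0.032 mg/kg

For the measured compounds named here, in a functional assay on the whole organism with Rattus norvegicus as the target (on this read-out lower numbers stand for an effect already at smaller amounts and higher numbers for an effect only at larger amounts of compound), compound 2 gives 0.032 mg/kg as the only actual number so far. Compound 1 gives < 0.1 mg/kg which is a limit of the assay and not a number.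

Compound 3 (`Cc1cc(Cl)c(NC(=O)N(Cc2ccc(Oc3ccc(F)cc3)cc2)C2CCCCCC2)c(Cl)n1`) has not yet been measured and differs from compound 2 in one place. On an amide-type nitrogen, a group of 11 heavy atoms gives way to a group of 9 heavy atoms (a group of 9 heavy atoms (6 carbon, 1 nitrogen, 2 chlorine; one six-membered aromatic ring with 1 hetero atom) in place of a group of 11 heavy atoms (8 carbon, 1 nitrogen, 2 oxygen; one six-membered aromatic ring with 1 hetero atom), on an amide-type nitrogen) and each group has one six-membered aromatic ring with 1 hetero atom.

Going by the values given here, no measured step between compounds that differ in one place is available, so the expectation rests on compound 2 at 0.032 mg/kg alone. A modest shift toward larger doses, not far beyond the scatter, is expected in this assay as the estimated change (a 1.9-fold higher number from compound 2 to compound 3 (0.27 log units; within the scatter)) for this exchange. For compound 3 the estimated value is 0.06 mg/kg with an expected range from 0.015 mg/kg to 0.3 mg/kg in this assay.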

Compound 3, dose for half-maximal effect: > 0.1 mg/kg
Compound 3 gave a limit, no number; the forecaster's own chance of this, stated with the estimate: 15%; middle value at least 1.6-fold (0.22 log units) from the limit.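

In this assay, for the compounds shown here, this is the first measured step at this place, on an amide-type nitrogen, and it reads an at least 3.1-fold higher number from compound 2 to compound 3 (0.49 log units; beyond the scatter). It shows that here the group of 9 heavy atoms with its 2 chlorine atoms does not stand in for the group of 11 heavy atoms with its 2 oxygen atoms without a clear move toward larger doses, even though both groups have one six-membered aromatic ring with 1 hetero atom. Compound 3 gives > 0.1 mg/kg, which is a limit of the assay and not a number, and the step is a lower bound only because of that limit: the limit of > 0.1 mg/kg in this assay, at which 1 of the 3 values shown sits.

Going by these compounds, how far compound 3 really lies from compound 2 stays open. Also open, on these data alone, is whether a ring carrying ethoxy or amino groups in place of the oxygen-bearing groups of compound 2 would hold its value in this assay.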